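Ester and nitrogen chain extension in a series at the limit

This account rests on a few compounds, and the source may have more. Where it says the series, first, only, none or still open, it means among the compounds named here.

Measured so far in a functional assay on cells (Platelet, Homo sapiens) for inhibition; a lower number here means a stronger inhibitor, a higher number a weaker inhibitor:
Compound 1, `CCOC(=O)c1ccc(-c2nn(CC)c3ccccc23)cc1`, gives > 10000 nM in this assay.
Compound 2, `CCCCn1nc(-c2ccc(C(=O)OCC)cc2)c2ccccc21`, gives > 10000 nM in this assay.
Compound 3, `COC(=O)c1ccc(-c2nn(Cc3ccccc3)c3ccccc23)cc1`, gives > 10000 nM in this assay.

Each of these three values is a limit of this assay, not a number; the whole set sits at the limit of > 10000 nM in this assay, at which 3 of the 3 values shown sit.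

Compound 1 and compound 2 differ in one place: ethyl in place of hydrogen on a saturated chain carbon, two bonds along the chain from an aromatic nitrogen. The step that the two limits leave unreadable from compound 1 to compound 2 is one that the two limits leave unreadable, so its size is not known.

Compound 3 differs from compound 1 in its core as well as in the ester; the difference between the two cores is not broken down here.

Compound 4, `CCCOC(=O)c1ccc(-c2nn(Cc3ccccc3)c3ccccc23)cc1`, is the one still to be measured. It differs from compound 3 by ethyl in place of hydrogen on a saturated chain carbon bound to an oxygen next to a carbonyl group. This is the same kind of change as that from compound 1 to compound 2, an ethyl in place of a hydrogen on a saturated chain carbon, but the place is not the same: in the earlier pair the carbon lies two bonds along the chain from an aromatic nitrogen, here it is bound to an oxygen next to a carbonyl group.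

The expectation for compound 4 rests on compound 3 giving > 10000 nM as a limit and on the earlier step of this kind being unreadable. The step that the limit leaves unreadable from compound 3 to compound 4 is therefore expected to be unreadable as well. Compound 4 is estimated at 15000 nM in this assay, with a range of 4000 nM to 60000 nM, most likely reported again only as a limit.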

Compound 4, half-maximal inhibitory concentration: > 10000 nM
Compound 4: only a limit was reported; the forecaster's own chance of this, stated with the estimate: 85%; the middle value lies beyond the limit too.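

In this assay compound 4 gives > 10000 nM, which is a limit of the assay and not a number. With compound 3 also at a limit, no step can be read between compound 3 and compound 4, and the whole set stands at a single limit: the limit of > 10000 nM in this assay, at which 4 of the 4 values shown sit.

The compounds shown leave open how large either chain extension is, and whether any compound in this series gives a measured number at all.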